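The compounds below may be only part of what the source reports. "The series", "measured", "known", "first", "only" and "open" are said of these compounds alone.

Measured so far:
compound 1 `Cc1nc(S(C)(=O)=O)ccc1Oc1ncnc(OC2CCN(C(=O)OC(C)F)CC2)c1F`: 315 nM in a functional assay on isolated protein for inhibition of Glucose-dependent insulinotropic receptor (Rattus norvegicus), read by HTRF and cAMP accumulation; on this read-out lower numbers stand for an effect already at smaller amounts and higher numbers for an effect only at larger amounts of compound
compound 2 `Cc1nc(S(C)(=O)=O)ccc1Oc1ncnc(OC2CCN(C(=O)SC3CCC3)CC2)c1F`: 77.4 nM in this assay

For the measured compounds named here, compound 2 stands at the lowest of the two numbers in this assay; the only other point is compound 1, and the gap between them is a 4.1-fold lower number from compound 1 to compound 2 (0.61 log units; beyond the scatter), a change confined to the group on the carbonyl carbon of the ring nitrogen.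

Compound 3 `Cc1nc(S(C)(=O)=O)ccc1Oc1ncnc(OC2CCN(C(=O)C3CCCC3)CC2)c1F` is the next variation at that same carbonyl carbon: cyclopentyl in place of cyclobutylsulfanyl on a carbonyl carbon. Going by the values given here, the single measured step at this position, a 4.1-fold lower number from compound 1 to compound 2 (0.61 log units; beyond the scatter), shows that exchanging the group on this carbonyl can move the number by a modest amount, but it does not involve the cyclopentyl group and gives no direction for a ring of carbon only in place of a sulfur-linked ring. With both groups of equal heavy-atom count, the expectation is a small step, a 1.3-fold higher number from compound 2 to compound 3 (0.11 log units; within the scatter), most likely within the scatter. Compound 3 is therefore estimated at 100 nM, within 35 nM to 300 nM.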

Compound 3, half-maximal effective concentration: 407 nM
Beside the measured number, compound 3's estimate is 4.1-fold (0.61 log units) below it, outside the stated range (above it).
By their numbers in this assay, from the lowest: compound 2; then compounds 1 and 3 (each within the scatter of the next).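

In this assay, matching heavy-atom count at this carbonyl carbon does not hold the number steady: cyclopentyl in place of cyclobutylsulfanyl gives a 5.3-fold higher number from compound 2 to compound 3 (0.72 log units; beyond the scatter). The other pair stays within the scatter (a 1.3-fold higher number from compound 1 to compound 3 (0.11 log units; within the scatter)), so among these three groups only the cyclobutylsulfanyl of compound 2 stands apart, while the groups of compound 1 and compound 3 cannot be told apart despite their different make-up. No measurement on hand accounts for this step.

The step from compound 2 to compound 3 changes the sulfur link and the ring size together, and the compounds shown do not separate the two. Cyclobutyl bonded directly to the carbonyl carbon, or cyclopentylsulfanyl, would pull these apart, and a pyrrolidine nitrogen on the carbonyl carbon remains an open comparison.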